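A Second Methoxy Group: Compound 2 to Compound 3

A few compounds are considered here, and "the series" means these few. Any claim that something is new, unique, unknown or untested is made for them only; others in the source may bear on it.

Compound 1 `Nc1ccc(-c2cn(-c3ccc(OC(F)(F)F)cc3)nn2)cc1` in a functional assay on MDA-MB-231 cells (Homo sapiens) for cytotoxicity, read by MTT assay (on this read-out higher numbers stand for weaker inhibition and lower numbers for stronger inhibition), gives > 10 nM, a limit.
Compound 2 `COc1ccc(-n2cc(-c3ccc(N)cc3)nn2)cc1` in this assay gives > 100 nM, also a limit.

Compound 2 therefore stands at the limit of > 100 nM in this assay, at which 1 of the 2 values shown sits, and has no number of its own. Within the data shown here, the only measured step, a step that the two limits leave unreadable from compound 1 to compound 2, runs between two limits and yields no readable size. Compound 3 `COc1ccc(-n2cc(-c3ccc(N)cc3)nn2)c(OC)c1` differs from compound 2 by methoxy in place of hydrogen on an aromatic carbon. Among the measured compounds shown here, no measured step shows how an added methoxy shifts potency here, so no direction beyond the scatter can be expected. Compound 3 is estimated at 5000 nM, within 300 nM to 50000 nM, most likely again reported only as a limit. The expected step is a step that the limit leaves unreadable from compound 2 to compound 3.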

Compound 3, half-maximal inhibitory concentration: > 10000 nM
Compound 3: only a limit was reported; the forecaster's own chance of this, stated with the estimate: 70%; middle value at least 2.0-fold (0.30 log units) from the limit.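

Compound 2 and compound 3 both stand only as limits, so the step between them cannot be read. The compounds shown leave open whether an added methoxy shifts potency at all, and what actual potency each compound has in this assay.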